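The compounds below may be only part of what the source reports. "The series", "measured", "known", "first", "only" and "open" are said of these compounds alone.

Working notes on the hexyl series sharing the core of compound 1 `CCCCCCc1cc2cn(COCCO)c(=O)nc2o1`. In a functional assay on HEL cells (Homo sapiens) (a lower number here means that less compound is tolerated, a higher number that more compound is tolerated), compound 1 stops at a limit of the assay, > 200000 nM. Compound 2 `CCCCCCCc1cc2cn(COCCO)c(=O)nc2o1` gives 140000 nM in this assay, the highest of the two numbers recorded in it. Compound 3 `CCCCCCCCC#Cc1cc2cn(COCCO)c(=O)nc2o1` gives 42000 nM in this assay; the gap from compound 2 to compound 3 is beyond the scatter. Among the compounds with values here, the one measured step, an at least 1.4-fold lower number from compound 1 to compound 2 (0.15 log units; that floor lies within the scatter), rests on a limit, as the limit of > 200000 nM in this assay, at which 1 of the 3 values shown sits, records, so its true size is unknown and only a floor is seen.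

Compound 4 `CCCCCCCCCc1cc2cn(COCCO)c(=O)nc2o1` differs from compound 2 by ethyl in place of hydrogen on a saturated chain carbon, seven bonds along the chain from an aromatic carbon. This is the same kind of chain lengthening as the measured step, cut one bond further out and with a longer group entering. With the measured step pointing toward a lower number and compound 3, carrying the longest chain, giving the lowest number in this assay, a further drop is expected, a 2.3-fold lower number from compound 2 to compound 4 (0.37 log units; beyond the scatter). Compound 4 is therefore estimated at 60000 nM, with a range from 25000 nM to 140000 nM in this assay.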

Compound 4, half-maximal cytotoxic concentration: >= 100000 nM
Compound 4 was reported as a limit (the forecaster's own chance of this, stated with the estimate: 5%); middle value at least 1.6-fold (0.22 log units) from the limit.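

Within the data shown here, compound 4 stops at a limit in this assay, >= 100000 nM, and no step from compound 2 or compound 1 to compound 4 can be read. The compounds shown leave open where the true value of compound 4 lies and whether it falls below that of compound 1, itself a limit.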